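The source may report more compounds than this note shows. Statements on the series, on what has been measured and on what is new or still open speak of the compounds shown alone.

Measured so far in a functional assay on PC-3 cells (Homo sapiens) for cytotoxicity, read by MTT assay, with a stated time of 72 h; a higher number here means a weaker inhibitor, a lower number a stronger inhibitor:

- compound 1, `COc1ccc(/C=C/C(=O)/C=C/C2=C(C)CCCC2(C)C)cc1OC`: 42000 nM
- compound 2, `CC1=C(/C=C/C(=O)/C=C/c2ccc(C(F)(F)F)cc2)C(C)(C)CCC1O`: 10200 nM
- compound 3, `CC1=C(/C=C/C(=O)/C=C/c2ccc(C(F)(F)F)cc2F)C(C)(C)CCC1O`: 4600 nM

Compound 2 stands second highest of the three numbers in this assay. Its nearest neighbour is compound 3, reached by a 2.2-fold lower number from compound 2 to compound 3 (0.35 log units; beyond the scatter). Among the compounds with values here, its furthest is compound 1, whose number is higher; the two have no single-point step between them, so only the two values themselves can be compared.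

Compound 4, `CC1=C(/C=C/C(=O)/C=C/c2ccc([N+](=O)[O-])cc2)C(C)(C)CCC1O`, differs from compound 2 in one place: nitro in place of trifluoromethyl on an aromatic carbon. Within the data shown here, no measured step concerns this exchange. Among the measured compounds shown here, the only step among the measured compounds, a 2.2-fold lower number from compound 2 to compound 3 (0.35 log units; beyond the scatter), is a modest change at a different position and leaves the trifluoromethyl in place, so it says nothing about what replacing that group by nitro does. With nothing in the measured steps bearing on the change, the expectation for compound 4 in this assay is a number close to that of compound 2, with no step beyond the scatter in either direction, though the range must be set wide.

The estimate for compound 4 in this assay is therefore 10000 nM, between 3000 nM and 35000 nM, corresponding to an expected step of a 1.0-fold lower number from compound 2 to compound 4 (0.01 log units; within the scatter).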

Compound 4, half-maximal inhibitory concentration: 15000 nM
Compound 4: middle estimate off by 1.5-fold (0.18 log units), on the low side; the measured number falls inside the stated range.
By their numbers in this assay, from the lowest: compound 3; then compounds 2 and 4 (each within the scatter of the next); then compound 1.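

In this assay, putting nitro in place of trifluoromethyl on the aromatic carbon para to a large group gives a 1.5-fold higher number from compound 2 to compound 4 (0.17 log units; within the scatter), so this exchange leaves the number within the scatter. Within the data shown here, the earlier step, a 2.2-fold lower number from compound 2 to compound 3 (0.35 log units; beyond the scatter), placed fluoro on another aromatic carbon and kept trifluoromethyl, whereas this is the first step to replace that group, and it shows that trifluoromethyl can give way to nitro without a change beyond the scatter in this assay. Nothing available explains why the two groups give numbers this close.

Going by these compounds, two groups at one position do not show how far this tolerance extends, and it remains open whether an amine or a carboxylic acid on the same carbon would also stay within the scatter of compound 2. On these data alone, it is also open whether fluoro added to compound 4 would produce a step like the one seen with trifluoromethyl in place, and compound 1, which differs from these compounds in more than one place, cannot settle either question.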